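The compounds below may be only part of what the source reports. "The series", "measured", "known", "first", "only" and "open" are said of these compounds alone.

Compound 1 `O=C(C1CCC(F)(F)CC1)N1CCc2nc(C#Cc3ccccc3)sc2C1`: > 10000 nM
Compound 2 `N#Cc1cccc(C(=O)N2CCc3nc(C#Cc4ccccc4)sc3C2)c1`: > 10000 nM

Both measured compounds were tested in an assay on HEK293 cells for negative allosteric modulation of metabotropic glutamate receptor 5 (Homo sapiens), read by FLIPR, with a stated time of 1 h; on this read-out higher numbers stand for weaker inhibition and lower numbers for stronger inhibition. In this assay compound 1 gives > 10000 nM, which is a limit of the assay and not a number. Compound 2 gives > 10000 nM in this assay, likewise a limit rather than a number. The step that the two limits leave unreadable from compound 1 to compound 2 therefore cannot be read; (the limit of > 10000 nM in this assay, at which 2 of the 2 values shown sit). Compound 2 thus stands at the limit, and nothing among the numbers shown places it more exactly than that.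

Compound 3 `Cc1cccc(C(=O)N2CCc3nc(C#Cc4ccccc4)sc3C2)n1` differs from compound 2 by 6-methylpyridin-2-yl in place of 3-cyanophenyl on a carbonyl carbon. No measured step bears on this change, and the only step shown is itself unreadable, so no size or direction beyond the scatter can be expected for it in this assay. Compound 3 is therefore expected to remain near the same limit, with an estimate of 15000 nM (from 4000 nM to 60000 nM), which means an expected step that the limit leaves unreadable from compound 2 to compound 3.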

Compound 3, half-maximal inhibitory concentration: > 10000 nM
Compound 3 ended at the assay's limit (the forecaster's own chance of this, stated with the estimate: 75%); the middle value is on the limit's open side.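

Among these compounds, compound 3 also sits at a limit of the assay and not at a number, so no step among compound 1, compound 2 and compound 3 can be read: the limit of > 10000 nM in this assay, at which 3 of the 3 values shown sit. The compounds shown leave open which group on the carbonyl carbon, if any, would give a measurable value in this assay.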